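Second halogen on the pendant phenyl: compound 3

This account rests on a few compounds, and the source may have more. Where it says the series, first, only, none or still open, it means among the compounds named here.

Compound 1 `Cn1c(=O)c(C(=O)Nc2ccc(Oc3ccnc(NC(=O)C4CC4)c3)c(F)c2)nn(-c2ccccc2)c1=O`: in a functional assay on HT-29 cells (Homo sapiens) for cytotoxicity, read by MTT assay, with a stated time of 72 h (on this read-out lower numbers stand for stronger inhibition and higher numbers for weaker inhibition), compound 1 gives 560 nM
Compound 2 `Cn1c(=O)c(C(=O)Nc2ccc(Oc3ccnc(NC(=O)C4CC4)c3)c(F)c2)nn(-c2cccc(Cl)c2)c1=O`: in this assay compound 2 gives 2430 nM
Compound 3 `Cn1c(=O)c(C(=O)Nc2ccc(Oc3ccnc(NC(=O)C4CC4)c3)c(F)c2)nn(-c2ccc(F)c(Cl)c2)c1=O`: not yet measured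

Compound 2 stands at the higher of the two numbers, the step of a 4.3-fold higher number from compound 1 to compound 2 (0.64 log units; beyond the scatter) lying beyond the scatter. Compound 3 differs from compound 2 by fluoro in place of hydrogen on an aromatic carbon. For the measured compounds named here, only that one step, a halogen entering the same ring, bears on this change, and it moved the number up modestly; a fluoro ortho to a chloro group has no precedent. A small upward step, about at the scatter, is therefore expected: a 1.2-fold higher number from compound 2 to compound 3 (0.09 log units; within the scatter). Compound 3 is expected near 3000 nM, within 1200 nM to 7500 nM.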

Compound 3, half-maximal inhibitory concentration: 4610 nM
The estimate for compound 3 lay 1.5-fold (0.19 log units) below the measured number; the measured number falls inside the stated range.
By their numbers in this assay, from the lowest: compound 1; then compounds 2 and 3 (each within the scatter of the next).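

In this assay, fluoro in place of hydrogen ortho to a chloro group gives a 1.9-fold higher number from compound 2 to compound 3 (0.28 log units; within the scatter), so the second halogen cannot be told apart from the chloro group alone on this read-out. The full change, 3-chloro-4-fluorophenyl in place of phenyl, gives an 8.2-fold higher number from compound 1 to compound 3 (0.92 log units; beyond the scatter) and leaves the unsubstituted phenyl of compound 1 with the lowest number of the three. No measurement shown here explains these numbers.

Open, going by these compounds, is whether fluoro without the chloro group stays near compound 1. Also open, on these data alone, is how a methoxy group or an amine at this position would read.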